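The compounds below may be only part of what the source reports. "The series", "measured", "known", "first", "only" and "open" are said of these compounds alone.

Working notes on the series. Compound 1 `COc1cccc(-c2nn3cc(-c4cccc(N)c4)nc3s2)c1` gives in a functional assay on CCRF-CEM cells (Homo sapiens) for inhibition, read by cell counting, with a stated time of 3 days (on this read-out lower numbers stand for stronger inhibition and higher numbers for weaker inhibition), only a limit, > 250000 nM, as recorded by the limit of > 250000 nM in this assay, at which 1 of the 3 values shown sits. Compound 2 `C=C(Br)C(=O)Nc1cccc(-c2cn3nc(-c4cccs4)sc3n2)c1` gives 410 nM in this assay, and compound 3 `C=C(Br)C(=O)Nc1cccc(-c2cn3nc(Cc4ccc(Cl)cc4)sc3n2)c1` gives 3300 nM. Among the two numbers shown, compound 3 stands highest, with compound 2 nearest and beyond the scatter; the one measured step, an 8.0-fold higher number from compound 2 to compound 3 (0.91 log units; beyond the scatter), is the only guide to the size of changes at this aromatic carbon.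

Compound 4 `C=C(Br)C(=O)Nc1cccc(-c2cn3nc(-c4cccc(OC)c4)sc3n2)c1` has not yet been measured. It differs from compound 3 by 3-methoxyphenyl in place of 4-chlorobenzyl on an aromatic carbon. The change reverses the direction of the measured step: the 4-chlorobenzyl that entered from compound 2 to compound 3 now leaves, and a six-membered aromatic ring, 3-methoxyphenyl, enters, closer in kind to the thiophen-2-yl of compound 2. Compound 1 carries the same 3-methoxyphenyl, but its limit gives no size. The step of an 8.0-fold higher number from compound 2 to compound 3 (0.91 log units; beyond the scatter) was modest but beyond the scatter, and a step of about that size in the opposite direction is expected in this assay, bringing compound 4 near compound 2. Compound 4 is therefore expected to give 600 nM in this assay, within 150 nM to 2500 nM, a step of a 5.5-fold lower number from compound 3 to compound 4 (0.74 log units; beyond the scatter).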

Compound 4, half-maximal inhibitory concentration: 1200 nM
For compound 4 the middle estimate is 2.0-fold (0.30 log units) below the measured one, and the stated range covers the measured number.
By their numbers in this assay, from the lowest: compound 2; then compound 4; then compound 3. At a limit, above all of these: compound 1.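

In this assay, the 3-methoxyphenyl at this aromatic carbon gives a 2.8-fold lower number from compound 3 to compound 4 (0.44 log units; beyond the scatter), yet also a 2.9-fold higher number from compound 2 to compound 4 (0.47 log units; beyond the scatter), so compound 4 falls between the two earlier compounds and the three groups now form an order with thiophen-2-yl lowest and 4-chlorobenzyl highest. The leaving and entering groups of the step to compound 4 have the same heavy-atom count and one six-membered aromatic ring each, so that count and ring alone do not fix the number at this carbon. With the 3-methoxyphenyl held constant, the (1-bromoethenyl)carbonyl on the nitrogen accounts for an at least 200-fold lower number from compound 1 to compound 4 (2.31 log units; beyond the scatter), the largest step in the series, although its size is bounded rather than exact, since compound 1 stands at a limit and not at a number: the limit of > 250000 nM in this assay, at which 1 of the 4 values shown sits.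

The compounds shown leave open whether plain phenyl, 4-methoxyphenyl or an unsubstituted benzyl at this carbon would fall within this order, and so whether the ring, its substituent or the methylene link sets the steps. They also leave open what an acetyl or a propenoyl on the nitrogen, without the bromine, would give in this assay.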